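The compounds below may be only part of what the source reports. "The series", "measured", "known", "first", "only" and "open" are said of these compounds alone.

Two members of one series have been measured in an assay on Cerebral cortex for displacement of a labelled ligand from adenosine receptor A1 (Bos taurus); a lower number here means a stronger inhibitor, a higher number a weaker inhibitor. Compound 1 `CCNc1nc(-c2ccccc2)nc2c1nnn2Cc1ccccc1` gives 91 nM in this assay, and compound 2 `CCCNc1nc(-c2ccccc2)nc2c1nnn2Cc1ccccc1` gives 37 nM. Within the data shown here, compound 2 thus stands lowest of the two numbers available; the only step that leads to it, a 2.5-fold lower number from compound 1 to compound 2 (0.39 log units; beyond the scatter), is a modest one in which a methyl is added to the chain on the nitrogen on the aromatic ring. The next compound, compound 3 `CCCCNc1nc(-c2ccccc2)nc2c1nnn2Cc1ccccc1`, carries the same kind of change placed three bonds along the chain from that nitrogen: methyl in place of hydrogen on a saturated chain carbon, three bonds along the chain from a nitrogen on an aromatic ring, which, cut one bond further out, reads methyl to ethyl, ethyl to propyl, propyl to butyl. Among the measured compounds shown here, the single measured step that bears on this change, a 2.5-fold lower number from compound 1 to compound 2 (0.39 log units; beyond the scatter), lay beyond the scatter but was modest, and there is no second step to show whether adding another methyl keeps lowering the number. A similar but smaller lowering in this assay is expected, with a real chance that the step stays within the scatter. The expected step is a 1.5-fold lower number from compound 2 to compound 3 (0.17 log units; within the scatter). Compound 3 is therefore estimated at 25 nM, within a range from 10 nM to 70 nM.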

Compound 3, inhibition constant: 11 nM
Estimate against measurement, compound 3: 2.3-fold (0.36 log units) above; low and high end bracket the measured number.
By their numbers in this assay, from the lowest: compound 3; then compound 2; then compound 1.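

In this assay the methyl added three bonds along the chain from the nitrogen on the aromatic ring gives a 3.4-fold lower number from compound 2 to compound 3 (0.53 log units; beyond the scatter) and so shows that the lowering is not confined to the place two bonds along the chain: a second step, also beyond the scatter, now runs in the same direction. Taken as one change, ethyl in place of hydrogen on the saturated chain carbon two bonds along the chain gives an 8.3-fold lower number from compound 1 to compound 3 (0.92 log units; beyond the scatter) and places the three compounds in a single order, with the number falling from the ethyl chain through the propyl chain to the butyl chain and no compound going against that order. Nothing available here explains why the number falls as the chain grows.

These three compounds leave open whether the number keeps falling with a pentyl or hexyl chain on the same nitrogen, or levels off or turns back upward. They also leave open whether the chain has to stay unbranched, a question that an isobutyl or cyclopentyl group in its place would address.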